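Series notes: methoxy step from compound 1 to compound 3

The source may report more compounds than this note shows. Statements on the series, on what has been measured and on what is new or still open speak of the compounds shown alone.

Measured so far:
- compound 1, `CC1(C)Cc2c(OCc3ccccc3)ccc(C(=O)/C=C/c3ccccc3)c2O1`: in a functional assay on NCI-H460 cells (Homo sapiens) for antiproliferative activity, read by MTT assay, with a stated time of 48 h (a lower number here means a stronger inhibitor, a higher number a weaker inhibitor), compound 1 gives > 100000 nM, which is a limit of the assay.
- compound 2, `CC1(C)Cc2c(ccc(C(=O)/C=C/c3ccccc3)c2OCc2ccccc2)O1`: in this assay compound 2 gives > 100000 nM, again a limit and not a number.

Compound 1 stands at the limit of > 100000 nM in this assay, at which 2 of the 2 values shown sit; no number has been obtained for it, only this limit. Among the compounds with values here, the two measured compounds carry the same benzyloxy chalcone arrangement on the shared core and differ in where the benzyloxy group sits; both sit at the limit, so no step between them is given and nothing about order can be read from the pair.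

Compound 3, `COc1ccc(/C=C/C(=O)c2ccc(OCc3ccccc3)c3c2OC(C)(C)C3)cc1`, differs from compound 1 by methoxy in place of hydrogen on an aromatic carbon, para to a large group, so that 2-phenylethenyl becomes 2-(4-methoxyphenyl)ethenyl. Within the data shown here, with both measured values at the limit there is no measured step to lean on. The expected step that the limit leaves unreadable from compound 1 to compound 3 is small, no more than the scatter, and most likely the assay again reports a limit. For compound 3 the estimate in this assay is 120000 nM, with a range from 30000 nM to 500000 nM.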

Compound 3, half-maximal inhibitory concentration: > 100000 nM
Compound 3: only a limit was reported (the forecaster's own chance of this, stated with the estimate: 80%); the middle value is on the limit's open side.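

In this assay compound 3 gives > 100000 nM as a limit and not a number. Within the data shown here, no step from compound 1 to compound 3 can be read, and the series stands as follows: the limit of > 100000 nM in this assay, at which 3 of the 3 values shown sit. The compounds shown leave open what methoxy in place of hydrogen does in this assay once a compound of the series gives a number there.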